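The source may hold more compounds than are shown below. What is called first, only, known or untested is meant among the compounds shown, and "the series" means these compounds.

Measured compounds in a functional assay on NCI-H1299 cells (Homo sapiens) for antiproliferative activity, read by MTT assay, with a stated time of 72 h; on this read-out higher numbers stand for weaker inhibition and lower numbers for stronger inhibition:
compound 1 `O=C(C1=C(OC2CCCCC2)C(=O)N(CCCn2ccnc2)C1c1ccc(Br)cc1)c1ccccc1` gives 19900 nM;
compound 2 `NC1=C(C(=O)c2ccccc2)C(c2ccc(Br)cc2)N(CCCn2ccnc2)C1=O` gives 169000 nM;
compound 3 `O=C(C1=C(Nc2cccc(Br)c2)C(=O)N(CCCn2ccnc2)C1c1ccc(Br)cc1)c1ccccc1` gives 11500 nM.

Among these three, compound 1 stands second highest: compound 3 lies near it, and compound 2 lies furthest away, with an 8.5-fold higher number from compound 1 to compound 2 (0.93 log units; beyond the scatter). The new compound 4 `O=C(C1=C(Nc2ccccc2Br)C(=O)N(CCCn2ccnc2)C1c1ccc(Br)cc1)c1ccccc1` differs from compound 1 in one place: (2-bromophenyl)amino in place of cyclohexyloxy on a double-bonded ring carbon. The closest measured guide is the step to compound 3, which also puts a bromophenylamino group on that ring carbon, with a 1.7-fold lower number from compound 1 to compound 3 (0.24 log units; within the scatter). The step to compound 2 shows a bare amino group is worse, but compound 4 keeps the bromophenyl group. No step beyond the scatter is therefore expected for a 1.4-fold lower number from compound 1 to compound 4 (0.15 log units; within the scatter). Compound 4 is estimated at 14000 nM, within 5000 nM to 40000 nM.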

Compound 4, half-maximal inhibitory concentration: 15600 nM
Beside the measured number, compound 4's estimate is 1.1-fold (0.05 log units) below it, and the stated range covers the measured number.
By their numbers in this assay, from the lowest: compounds 3, 4 and 1 (each within the scatter of the next); then compound 2.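

In this assay, 2-bromophenyl in place of 3-bromophenyl on the amine nitrogen gives a 1.4-fold higher number from compound 3 to compound 4 (0.13 log units; within the scatter), so these two bromine placements cannot be told apart here. A bromophenyl group on that nitrogen clearly matters compared with hydrogen, with an 11-fold lower number from compound 2 to compound 4 (1.03 log units; beyond the scatter), yet replacing cyclohexyloxy gives only a 1.3-fold lower number from compound 1 to compound 4 (0.11 log units; within the scatter). No measured evidence explains these results. Still open, on these data alone, is whether the bromine itself matters, which a plain phenylamino group would test. A cyclohexylamino group would likewise show whether the ring needs to be aromatic.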